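This account rests on a few compounds, and the source may have more. Where it says the series, first, only, none or still open, it means among the compounds named here.

Compound 1 `CC1(C)C=Cc2c(ccc(C(=O)/C=C/c3ccc(Cl)cc3Cl)c2O)O1` gives 131000 nM
Compound 2 `CC1(C)C=Cc2c(ccc(C(=O)/C=C/c3ccc(C#N)cc3)c2O)O1` gives 80200 nM

In an ADME assay on Vero cells (Chlorocebus sabaeus) for cytotoxicity, read by MTT assay, with a stated time of 72 h (on this read-out higher numbers stand for lower toxicity in this test and lower numbers for higher toxicity in this test), compound 2 gives 80200 nM while compound 1 gives 131000 nM and these two numbers stand level within the usual scatter of repeated measurements. For the measured compounds named here, compound 2 therefore has only one measured neighbour, and it cannot be told apart from that neighbour.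

Compound 3 `CC1(C)C=Cc2c(ccc(C(=O)/C=C/c3ccccn3)c2O)O1` has not been measured yet. It carries pyridin-2-yl in place of 4-cyanophenyl on a double-bonded chain carbon bound to a double-bonded chain carbon, and the count of that swap reads pyridin-2-yl in place of 4-cyanophenyl on a double-bonded chain carbon bound to a double-bonded chain carbon with the rest of the molecule unchanged.

Going by the values given here, only one measured step bears on this, a change at that same place on the chain, namely a 1.6-fold lower number from compound 1 to compound 2 (0.21 log units; within the scatter) and it gives no sign of a large effect there. Among the compounds with values here, no compound with pyridin-2-yl has been measured, so the expectation rests on that single step. The expected change is a 1.1-fold higher number from compound 2 to compound 3 (0.05 log units; within the scatter) in this assay with no clear direction and nothing expected beyond the scatter. The estimated value for compound 3 is 90000 nM with an expected range from 40000 nM to 200000 nM in repeat measurements.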

Compound 3, half-maximal cytotoxic concentration: 20500 nM
For compound 3 the middle estimate is 4.4-fold (0.64 log units) above the measured one; measured number below the stated range.
By their numbers in this assay, from the lowest: compound 3; then compounds 2 and 1 (each within the scatter of the next).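

The group on this chain carbon can matter in this assay: the earlier swap between two substituted phenyl rings stayed within the scatter, whereas pyridin-2-yl gives the first clear shifts here (a 3.9-fold lower number from compound 2 to compound 3 (0.59 log units; beyond the scatter)) and (a 6.4-fold lower number from compound 1 to compound 3 (0.81 log units; beyond the scatter)). A lower number on this read-out stands for higher toxicity in this test, so compound 3 is the most toxic of the three, while compound 1 and compound 2, whose rings contain carbon only, remain level with each other. Nothing measured here explains why the pyridin-2-yl compound stands apart.

Pyridin-2-yl differs from the other two groups both in having a ring nitrogen and in lacking the chloro or nitrile substituents, so these three compounds cannot show which difference goes with the shift. An unsubstituted phenyl at this place would help separate the two, and pyridin-4-yl would show whether the result holds when the ring is attached differently, but how either group would behave remains an open question.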